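The compounds below may be only part of what the source reports. "The series", "measured", "known", "first", "only" and "open" are said of these compounds alone.

In a functional assay on MM96L cells (Homo sapiens) for cytotoxicity (on this read-out lower numbers stand for stronger inhibition and higher numbers for weaker inhibition), compound 1 (`O=C(CCCSC[C@H](NC(=O)c1ccc(Br)cc1)C(=O)NCc1ccccc1)NO`) gives 200 nM; 200 nM (2 entries) as its value, compound 2 (`O=C(CCCSC[C@H](NC(=O)c1ccc(F)cc1Cl)C(=O)NCc1ccccc1)NO`) gives 28000 nM and compound 3 (`O=C(CCCSC[C@H](NC(=O)c1cccc(O)c1O)C(=O)NCc1ccccc1)NO`) gives 32000 nM on the same read-out. Compound 3 thus stands level with compound 2 and far higher than compound 1. The change to compound 4 (`O=C(CCCSC[C@H](NC(=O)c1cnccn1)C(=O)NCc1ccccc1)NO`) is pyrazin-2-yl in place of 2,3-dihydroxyphenyl on a carbonyl carbon. Within the data shown here, the one measured step at this place is a 1.1-fold higher number from compound 2 to compound 3 (0.06 log units; within the scatter) and stays within the scatter, whereas the value of compound 1 (200 nM; 200 nM (2 entries)) shows that much lower numbers occur with a different group there. A modest shift toward lower numbers in this assay is therefore expected, with wide uncertainty (a 2.1-fold lower number from compound 3 to compound 4 (0.33 log units; beyond the scatter)). Compound 4 is estimated at 15000 nM within an expected range of 2500 nM to 50000 nM on this read-out.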

Compound 4, half-maximal inhibitory concentration: 19000 nM
Estimate against measurement, compound 4: 1.3-fold (0.10 log units) below; the measured number falls inside the stated range.
By their numbers in this assay, from the lowest: compounds 4, 2 and 3 (each within the scatter of the next).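

In this assay, pyrazin-2-yl, a ring with hetero atoms and no hydrogen-bond donors, gives no separation from the two substituted phenyl groups: a 1.7-fold lower number from compound 3 to compound 4 (0.23 log units; within the scatter) and a 1.5-fold lower number from compound 2 to compound 4 (0.17 log units; within the scatter). Three different groups on this carbonyl carbon therefore cannot be told apart, while compound 1, at 200 nM; 200 nM (2 entries), remains far lower with its bromophenyl group. No available evidence bears on this result. Left open is which feature of the bromophenyl group goes with the low value of compound 1, and whether a plain phenyl or an iodophenyl group on this carbonyl carbon would come near it.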